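One more methoxy on compound 2

The source may hold more compounds than are shown below. What is called first, only, known or untested is meant among the compounds shown, and "the series" means these compounds.

Measured so far in a functional assay on liver (Rattus norvegicus) for inhibition, with a stated time of 1 h (on this read-out higher numbers stand for an effect only at larger amounts of compound and lower numbers for an effect already at smaller amounts), are these compounds
Compound 1 `COc1cc([C@@H]2Oc3cc(OC)c(O)c(OC)c3C(=O)[C@@H]2O)ccc1O` gives 1900 nM
Compound 2 `COc1ccc([C@@H]2Oc3cc(OC)c(OC)c(OC)c3C(=O)[C@@H]2O)cc1OC` gives 28600 nM
Compound 3 `COc1cc([C@H]2Oc3cc(OC)c(OC)c(OC)c3C(=O)[C@@H]2O)ccc1O` gives 5500 nM

Compound 2 stands highest of the three (28600 nM), and both compound 3 and compound 1 lie lower, beyond the usual scatter. Compound 4 `COc1cc([C@@H]2Oc3cc(OC)c(OC)c(OC)c3C(=O)[C@@H]2O)cc(OC)c1OC` has not yet been measured. It departs from compound 2 in a single place, and the change is methoxy in place of hydrogen on an aromatic carbon (methoxy in place of hydrogen on an aromatic carbon, ortho to a methoxy group). Within the data shown here, no pair of measured compounds differs in one place, so the data show nothing directly about this change. The expectation therefore stays with compound 2 (28600 nM), and no step beyond the scatter, in either direction, is expected in this assay for this change. The estimated step is a 1.1-fold lower number from compound 2 to compound 4 (0.06 log units; within the scatter) and it remains uncertain. For compound 4 the expected value is 25000 nM with an estimated range from 9000 nM to 70000 nM in the coming measurement.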

Compound 4, half-maximal effective concentration: 19600 nM
Compound 4: the middle estimate sits 1.3-fold (0.11 log units) above what was measured, and the stated range covers the measured number.
By their numbers in this assay, from the lowest: compound 1; then compound 3; then compounds 4 and 2 (each within the scatter of the next).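

In this assay, methoxy in place of hydrogen on an aromatic carbon, ortho to a methoxy group, comes to a 1.5-fold lower number from compound 2 to compound 4 (0.16 log units; within the scatter). This gives the series its first pair differing in one place, and at this position, on a ring already carrying methoxy groups, the added methoxy leaves compound 2 and compound 4 within the usual scatter of each other. Nothing available bears on why the two read alike.

As far as these compounds go, whether a different group at this position, such as an amine or a carboxylic acid, would take the number beyond the scatter stays open. Also open, from the compounds shown here alone, is whether the same methoxy would read alike on compounds that keep a free hydroxy group on this ring, as compound 1 and compound 3 do.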